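Compound 4: cyclohexyl in place of 2-methoxyphenyl

The compounds below may be only part of what the source reports. "The series", "measured", "known", "first", "only" and "open" are said of these compounds alone.

The series shares one core and is varied at the second acyl group. Compound 1 `CC(C)(C)N(NC(=O)c1ccccc1)C(=O)c1ccccc1Br` gives 170 nM in an assay on cells for agonist activity at ecdysone receptor (Bombyx mori), read by a luciferase reporter, with a stated time of 24 h; a higher number here means that more compound is needed for the effect, a lower number that less compound is needed; compound 2 `Cc1ccccc1C(=O)N(NC(=O)c1ccccc1)C(C)(C)C` gives 224 nM; compound 3 `COc1ccccc1C(=O)N(NC(=O)c1ccccc1)C(C)(C)C` gives 525 nM. Compound 3 stands highest of the three numbers: a 2.3-fold higher number from compound 2 to compound 3 (0.37 log units; beyond the scatter) and a 3.1-fold higher number from compound 1 to compound 3 (0.49 log units; beyond the scatter), both modest, while a 1.3-fold higher number from compound 1 to compound 2 (0.12 log units; within the scatter) lies within the scatter.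

Compound 4 `CC(C)(C)N(NC(=O)c1ccccc1)C(=O)C1CCCCC1` differs from compound 3 by cyclohexyl in place of 2-methoxyphenyl on a carbonyl carbon. Among the compounds with values here, none of the measured steps bears on this change directly: each of them swaps one substituent on an aromatic ring for another, whereas here the aromatic ring with its methoxy leaves and a saturated ring enters. The measured steps only span the distance between compound 1 and compound 3 and give no guide to the loss of the aromatic ring, so the expected step carries a wider range than any of them. Given that compound 3 already gives the highest number, 525 nM, a further rise is expected for compound 4 in this assay, though the direction is not secured by any measured pair. The estimate for compound 4 is 1200 nM, with a range from 250 nM to 6000 nM. This estimate amounts to a 2.3-fold higher number from compound 3 to compound 4 (0.36 log units; beyond the scatter).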

Compound 4, half-maximal effective concentration: 46800 nM
Compound 4: the middle estimate sits 39-fold (1.59 log units) below what was measured; the whole stated range lies below it.
By their numbers in this assay, from the lowest: compounds 1 and 2 (each within the scatter of the next); then compound 3; then compound 4.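

In this assay, within the data shown here, the earlier steps only exchanged one substituent on an aromatic ring and stayed within the scatter or modest, with a 3.1-fold higher number from compound 1 to compound 3 (0.49 log units; beyond the scatter) as the largest of them. Cyclohexyl in place of the substituted aromatic ring on the carbonyl carbon produces a step of another order, giving an 89-fold higher number from compound 3 to compound 4 (1.95 log units; beyond the scatter) and a 210-fold higher number from compound 2 to compound 4 (2.32 log units; beyond the scatter) and a 280-fold higher number from compound 1 to compound 4 (2.44 log units; beyond the scatter) in turn. Among these four compounds, whether an aromatic ring stands on this carbonyl carbon therefore counts for far more than whether that ring carries bromo, methyl or methoxy, and nothing at hand explains the size of this step.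

The compounds shown leave open whether an unsubstituted phenyl, a pyridine ring or a cyclohexene ring on the same carbonyl carbon would stay close to compounds 1, 2 and 3 or move towards compound 4. They also leave open whether a methyl group or a methoxy group on the cyclohexyl ring, or a longer open chain in its place, would recover any of the lost ground.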